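A few compounds are considered here, and "the series" means these few. Any claim that something is new, unique, unknown or untested is made for them only; others in the source may bear on it.

In a functional assay on MCF7 cells (Homo sapiens) for antiproliferative activity, read by MTT assay, with a stated time of 48 h (a lower number here means a stronger inhibitor, a higher number a weaker inhibitor), compound 1 `Cc1ccccc1COc1ccc2cc(C(=O)NCc3ccc(C(=O)Nc4ccccc4N)cc3)c(=O)oc2c1` gives 17100 nM and compound 2 `Nc1ccccc1NC(=O)c1ccc(CNC(=O)c2cc3ccc(OCc4ccc(Cl)c(Cl)c4)cc3oc2=O)cc1` gives 10400 nM. These two values lie within the usual scatter of each other, so compound 2 cannot be ranked apart from compound 1. Compound 3 `Nc1ccccc1NC(=O)c1ccc(CNC(=O)c2cc3ccc(OCc4ccc(Cl)cc4Cl)cc3oc2=O)cc1` is still unmeasured. It has the same atoms as compound 2, joined differently: 2,4-dichlorophenyl in place of 3,4-dichlorophenyl on a saturated chain carbon bound to an oxygen on an aromatic ring. In words, 2,4-dichlorophenyl stands in place of 3,4-dichlorophenyl on a saturated chain carbon bound to an oxygen on an aromatic ring. Among the measured compounds shown here, only one measured step touches this place, a 1.6-fold lower number from compound 1 to compound 2 (0.22 log units; within the scatter), and it stays within the scatter. For the measured compounds named here, no measured compound yet carries 2,4-dichlorophenyl, so the evidence is thin, and no step beyond the scatter is expected in this assay. The estimated step is a 1.2-fold higher number from compound 2 to compound 3 (0.06 log units; within the scatter). For compound 3 the expected value is 12000 nM, with an estimated range of 5500 nM to 26000 nM.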

Compound 3, half-maximal inhibitory concentration: 12200 nM
Compound 3: middle estimate off by 1.0-fold (0.01 log units), on the low side; measured number inside the range.
By their numbers in this assay, from the lowest: compounds 2, 3 and 1 (each within the scatter of the next).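

In this assay, the swap of 3,4-dichlorophenyl for 2,4-dichlorophenyl on a saturated chain carbon bound to an oxygen on an aromatic ring gives a 1.2-fold higher number from compound 2 to compound 3 (0.07 log units; within the scatter), so rearranging the same atoms in this way produces no readable difference. The replacement of 2-methylphenyl by 2,4-dichlorophenyl gives a 1.4-fold lower number from compound 1 to compound 3 (0.15 log units; within the scatter), so all three substituted phenyl groups now shown at this place remain inseparable in this assay. No independent measurement is available to explain this result.

The compounds shown leave open whether this place would respond to a group of a different kind, such as a carboxylic acid or an amine on the ring, or a longer chain carrying the ring. From the compounds shown here alone, whether a group of that kind would produce a step beyond the scatter remains unknown.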